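Exchanging one side chain for another on a shared core

The compounds below may be only part of what the source reports. "The series", "measured", "known", "first", "only" and "open" are said of these compounds alone.

Measured so far:
compound 1, `COc1ccc(N(C)c2nc(C)nc3ccccc23)cc1C(=O)OCC[Se]C#N`, 951 nM
compound 2, `Cc1nc(N(C)c2ccc(OCC[Se]C#N)cc2)c2ccccc2n1`, 2290 nM

Both compounds were tested in a functional assay on HCT-116 cells (Homo sapiens) for inhibition, read by MTT assay, with a stated time of 48 h; a higher number here means a weaker inhibitor, a lower number a stronger inhibitor. Compound 1 gives 951 nM in this assay, and compound 2 gives 2290 nM. Compound 1 therefore has the lower of the two numbers, and its gap to compound 2 is beyond the usual scatter, so compound 1 is the stronger inhibitor of this pair. The two structures differ in more than one place, so nothing can be said about which part of that difference matters.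

Compound 3, `COc1ccc(N(C)c2nc(C)nc3ccccc23)cc1OCCCCC[Se]C#N`, has not yet been measured. It comes from compound 1 by a single change: a group of 9 heavy atoms (6 carbon, 1 nitrogen, 1 oxygen, 1 selenium; no ring) in place of a group of 8 heavy atoms (4 carbon, 1 nitrogen, 2 oxygen, 1 selenium; no ring), on an aromatic carbon. The entering chain is longer in carbon and carries no double bond outside aromatic rings, as the counted difference shows.

Going by the values given here, no measured step between compounds that differ in one place exists, so the size of this step cannot be read from a comparable pair. Compound 2 gives a higher number than compound 1, but it differs in more than one place and offers only a loose hint. A modest step toward a weaker inhibitor is expected, a 1.6-fold higher number from compound 1 to compound 3 (0.20 log units; within the scatter). Compound 3 is estimated at 1500 nM, with a range from 600 nM to 4000 nM.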

Compound 3, half-maximal inhibitory concentration: 256 nM
Compound 3: middle estimate off by 5.9-fold (0.77 log units), on the high side; measured number outside the range, below it.
By their numbers in this assay, from the lowest: compound 3; then compound 1; then compound 2.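

On the aromatic carbon ortho to a methoxy group, exchanging the group of 8 heavy atoms for the group of 9 heavy atoms gives a 3.7-fold lower number from compound 1 to compound 3 (0.57 log units; beyond the scatter) in this assay. Going by these compounds alone, this is the first comparison here between compounds that differ in one place, and it shows that the side chain at this position can change the reading by more than the usual scatter. The exchange alters several counted features at once: the entering group has more carbon, lacks the double bond of the leaving group and has one hydrogen-bond acceptor fewer, and no measurement available here explains the step or separates these features.

The compounds shown leave open which of those features matters, a question that an amide-linked chain of similar size could help to address. They also leave open whether a shorter or a longer carbon chain at this position would lower the number further, and whether a chain ending in a plain methyl group, without the selenium and nitrile, would keep the lower number of compound 3.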